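Dropping One Trifluoromethyl From Compound 2

This account rests on a few compounds, and the source may have more. Where it says the series, first, only, none or still open, it means among the compounds named here.

Compound 1 `O=C(Nc1cccc(-n2cc(-c3ccncc3)c(-c3cc(O)cc(Cl)c3)n2)c1)Nc1ccc(Cl)c(Cl)c1` and compound 2 `COc1cc(Cl)cc(-c2nn(-c3cccc(NC(=O)Nc4cc(C(F)(F)F)cc(C(F)(F)F)c4)c3)cc2-c2ccncc2)c1` share a core and differ only in their outer groups. In a functional assay on SF-295 cells (Homo sapiens) for inhibition, read by sulforhodamine B assay, with a stated time of 48 h, tested at 0.01 uM (on this read-out higher numbers stand for a weaker effect at the one concentration tested and lower numbers for a stronger effect), compound 1 gives 92% and compound 2 gives 95%; compound 2 holds the highest of the two numbers, and the nearest, compound 1, lies within the scatter of it. Compound 3 `COc1cc(Cl)cc(-c2nn(-c3cccc(NC(=O)Nc4cccc(C(F)(F)F)c4)c3)cc2-c2ccncc2)c1` differs from compound 2 by hydrogen in place of trifluoromethyl on an aromatic carbon. For the measured compounds named here, no measured pair shows this change, so the step from compound 2 to compound 3 in this assay is expected to stay within the scatter, at no change at the digits printed from compound 2 to compound 3 (within the scatter). Compound 3 is estimated at 95%, ranging from 85% to 103%.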

Compound 3, a percentage reported as activity, at one concentration (the size of the read-out at that concentration, not a potency): 94%
Estimate against measurement, compound 3: 1 percentage points above; the measured number falls inside the stated range.
By their numbers in this assay, from the lowest: compounds 1, 3 and 2 (each within the scatter of the next).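

In this assay, hydrogen in place of trifluoromethyl on an aromatic carbon gives a number 1 percentage points lower from compound 2 to compound 3 (within the scatter). For the compounds shown here, this is the first comparison that isolates one change, since compound 1 and compound 2 differ in several outer groups; at this position and the one concentration tested, the two compounds cannot be told apart. No measurement here offers an explanation for this result.

On these data alone, whether an amine or a carboxylic acid on this carbon would give a similar reading remains open. So does the outcome at higher concentrations, where compound 2 and compound 3 might separate.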